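The compounds below may be only part of what the source reports. "The series", "measured", "known", "first", "only" and "open" are said of these compounds alone.

Measured in a functional assay on K562 cells (Homo sapiens) for cytotoxicity, read by trypan blue exclusion, with a stated time of 96 h; a higher number here means a weaker inhibitor, a lower number a stronger inhibitor:
- compound 1 `COc1cc(OC)c(/C=C/S(=O)(=O)Nc2ccc(F)c(N)c2)c(OC)c1`: 5000 nM
- compound 2 `COc1ccc(NS(=O)(=O)/C=C/c2c(F)c(F)c(F)c(F)c2F)cc1[N+](=O)[O-]`: 100000 nM
- compound 3 `COc1ccc(/C=C/S(=O)(=O)Nc2c(F)c(F)c(F)c(F)c2F)cc1[N+](=O)[O-]`: 75000 nM

Compound 3 holds the second highest of these three numbers, but that rank means little on one side. Compound 3 gives 75000 nM, and compound 2 at 100000 nM lies within the usual scatter of it, so the two cannot be told apart. Compound 1 at 5000 nM has a much lower number, beyond the scatter.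

The unmeasured compound 4 `COc1ccc(/C=C/S(=O)(=O)Nc2c(F)c(F)c(F)c(F)c2F)cc1N` keeps all of compound 3 except one group. It has amino in place of nitro on an aromatic carbon, ortho to a methoxy group (amino in place of nitro on an aromatic carbon). Among the compounds with values here, no two measured compounds differ in only one place, so this swap has no direct precedent here. Within the data shown here, the only hint is compound 1, which also carries an amino group and gives 5000 nM, although it differs from compound 3 elsewhere too. A moderate fall in the number is therefore expected in this assay, probably beyond the scatter, and the estimated step is a 3.8-fold lower number from compound 3 to compound 4 (0.57 log units; beyond the scatter). For compound 4 the estimated value is 20000 nM, with an expected range of 4000 nM to 80000 nM.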

Compound 4, half-maximal inhibitory concentration: 35000 nM
Beside the measured number, compound 4's estimate is 1.8-fold (0.24 log units) below it; low and high end bracket the measured number.
By their numbers in this assay, from the lowest: compound 1; then compound 4; then compounds 3 and 2 (each within the scatter of the next).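

In this assay, within the data shown here, the step from nitro to amino on this aromatic carbon, ortho to a methoxy group, gives the first comparison in this set where only one place differs: a 2.1-fold lower number from compound 3 to compound 4 (0.33 log units; beyond the scatter). This shows that the number does respond to the group held at this position, with the rest of the molecule unchanged, although the step is modest and compound 4 still gives 35000 nM. Nothing measured here accounts for the size or direction of this step.

One pair gives one step, so it cannot show how the number would respond to other groups on this carbon, such as a hydroxyl group, a methyl group or an acetamide, or whether any of them would give a lower number than amino does. Going by these compounds, it also remains open whether amino in place of nitro would give a similar step in compound 2, which carries its nitro group ortho to a methoxy group as well, but differs from compound 3 elsewhere in the molecule.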